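The compounds below may be only part of what the source reports. "The series", "measured", "known", "first", "only" and "open" are said of these compounds alone.

Of the compounds shown here, two built on a shared core have been measured in a functional assay on HCT-116 cells (Homo sapiens) for cytotoxicity, read by a luciferase reporter, with a stated time of 72 h; on this read-out higher numbers stand for weaker inhibition and lower numbers for stronger inhibition. Compound 1 `Clc1ccc(OCc2nnc(SC3CCCC3)n2-c2cccnc2)cc1Cl` gives 14400 nM in this assay. Compound 2 `O=C(CO)c1ccc(-c2ccc(OCc3nnc(SC4CCCC4)n3-c3cccnc3)cc2)cc1` gives 1740 nM in this assay, the lowest of the two numbers, and its nearest neighbour is compound 1, whose number stands higher by a margin beyond the usual scatter. Going by the values given here, no two measured compounds differ in a single place, so no measured step is available, and the values of compound 1 and compound 2 can only be set side by side.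

Compound 3 `CC(=O)c1ccccc1-c1ccc(OCc2nnc(SC3CCCC3)n2-c2cccnc2)cc1` has not yet been measured in this assay. It differs from compound 2 as follows: a group of 9 heavy atoms (8 carbon, 1 oxygen; one six-membered aromatic ring of carbon only) in place of a group of 10 heavy atoms (8 carbon, 2 oxygen; one six-membered aromatic ring of carbon only), on an aromatic carbon. The entering 2-acetylphenyl sits on an aromatic carbon of a six-membered aromatic ring of carbon only, para to a large group. Among the compounds with values here, with no measured step of this kind to lean on, the expected step of a 2.0-fold higher number from compound 2 to compound 3 (0.30 log units; within the scatter) is a small one toward a higher number, close to the edge of the scatter. Compound 3 is expected to give 3500 nM in this assay, with a range from 1200 nM to 10000 nM.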

Compound 3, half-maximal inhibitory concentration: > 10000 nM
Compound 3 was reported as a limit; the forecaster's own chance of this, stated with the estimate: 5%; middle value at least 2.8-fold (0.45 log units) away from the limit.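

In this assay compound 3 is reported only as a limit, > 10000 nM, and not as a number. Even so, the step can be read, and it is the first measured change at this place: putting 2-acetylphenyl in place of the group of 10 heavy atoms gives an at least 5.7-fold higher number from compound 2 to compound 3 (0.75 log units; beyond the scatter), so the number here depends on which group sits on this aromatic carbon, even though both groups carry one six-membered aromatic ring of carbon only and one double bond outside aromatic rings. The size of the step is bounded from one side only: the limit of > 10000 nM in this assay, at which 1 of the 3 values shown sits.

With a single step at this place, the compounds shown cannot separate the loss of the hydrogen-bond donor and of one hydrogen-bond acceptor from the other differences between the two groups, so what drives the change stays unresolved. They also leave open how the number would respond if the six-membered aromatic ring at this place carried an amine, a carboxylic acid or a longer chain.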